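Trimethoxyphenyl for Isopropylphenyl on a Shared Core

This account rests on a few compounds, and the source may have more. Where it says the series, first, only, none or still open, it means among the compounds named here.

Compound 1 `Cc1ccc(Nc2nc(SCc3cn(Cc4ccccc4Cl)nn3)nc(-c3ccc(C(C)C)cc3)c2C#N)cc1`: > 64000 nM
Compound 2 `COc1ccc(Nc2nc(SCc3cn(Cc4ccccc4Cl)nn3)nc(-c3ccc(C(C)C)cc3)c2C#N)cc1`: > 64000 nM

In a functional assay on MGC-803 cells (Homo sapiens) for inhibition, read by MTT assay, with a stated time of 72 h (a higher number here means a weaker inhibitor, a lower number a stronger inhibitor), compound 1 gives > 64000 nM, which is a limit of the assay rather than a number. Compound 2 also sits at the limit with > 64000 nM. Both results rest on (the limit of > 64000 nM in this assay, at which 2 of the 2 values shown sit), so the step that the two limits leave unreadable from compound 1 to compound 2 cannot be read, and compound 1 stands only at a limit among the values shown.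

Compound 3 `COc1cc(-c2nc(SCc3cn(Cc4ccccc4Cl)nn3)nc(Nc3ccc(C)cc3)c2C#N)cc(OC)c1OC` is not yet measured. It differs from compound 1 by 3,4,5-trimethoxyphenyl in place of 4-isopropylphenyl on an aromatic carbon. Going by the values given here, none of the measured steps touches this position, and the one measured step is itself unreadable, so no size or direction can be carried over to this assay. Compound 1 offers only a limit as a starting point, and the change to compound 3 lies outside what the measured pair covers.

With this little to lean on, compound 3 is expected to land near 30000 nM, within 3000 nM to 100000 nM, an estimated step of an at least 2.1-fold lower number from compound 1 to compound 3 (0.32 log units; beyond the scatter).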

Compound 3, half-maximal inhibitory concentration: 30800 nM
The estimate for compound 3 lay 1.0-fold (0.01 log units) below the measured number; low and high end bracket the measured number.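

In this assay, compound 3 is the only one of the three compounds shown that gives a real number rather than a limit, so this position on the shared core, ortho to a cyano group, is the one place where a change can so far be read. Putting 3,4,5-trimethoxyphenyl in place of 4-isopropylphenyl gives an at least 2.0-fold lower number from compound 1 to compound 3 (0.31 log units; beyond the scatter) and so moves the result toward stronger inhibition, while the methoxy-for-methyl step between compound 1 and compound 2 cannot be read. The true size of the new step may be larger than printed, because compound 1 has only a limit and no number of its own: the limit of > 64000 nM in this assay, at which 2 of the 3 values shown sit.

As far as these compounds go, it remains open whether all the methoxy groups of the 3,4,5-trimethoxyphenyl are needed, or whether a single methoxy, a hydroxy or an amine on that phenyl ring would give the same shift. Also open, from the compounds shown here alone, is whether compound 3, at 30800 nM, can be improved further, for example by a carboxylic acid at this position or by changing the (4-methylphenyl)amino group now that a readable number exists as a starting point.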